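A Second Methoxy Group Added to Compound 2

A few compounds are considered here, and "the series" means these few. Any claim that something is new, unique, unknown or untested is made for them only; others in the source may bear on it.

Within the data shown here, compound 2 `COc1ccc(-c2nnc(SCC(=O)Nc3ccc(/C(C)=N/O)cc3)n2-c2ccccc2)cc1` is one of two compounds measured in a functional assay on the whole organism (strain albino) for inhibition, with Rattus norvegicus as the target, read by paw edema, with stated times of 30 min and 2 h, at a dose of 0.28 mmol/kg by the oral route (a higher number here means more inhibition at the dose given (going by the name of the read-out), a lower number less inhibition), where compound 2 gives 56%. The other is compound 1 `C/C(=N\O)c1ccc(NC(=O)CSc2nnc(-c3ccccc3)n2-c2ccccc2)cc1`, which in this assay gives 52%. Compound 2 stands highest of the two numbers, but only by a number 4 percentage points higher from compound 1 to compound 2 (within the scatter), so the two values cannot be told apart on this read-out.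

Compound 3 `COc1ccc(-c2nnc(SCC(=O)Nc3ccc(/C(C)=N/O)cc3)n2-c2ccccc2)cc1OC` has not yet been measured in this assay. It differs from compound 2 in one place: methoxy in place of hydrogen on an aromatic carbon. Among the measured compounds shown here, the single measured step, from compound 1 to compound 2, bears directly on this change, since it too put a methoxy group in place of hydrogen on an aromatic carbon of the same ring, and that step stayed within the scatter.

On this basis the expected step, a number 2 percentage points higher from compound 2 to compound 3 (within the scatter), is one that does not rise above the scatter in either direction. For compound 3 the estimate in this assay is therefore 58%, with a range from 44% to 72%, pending the measurement.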

Compound 3, a percentage reported as inhibition, in the whole organism at one dose (the size of the read-out at that dose, not a potency): 63%
Estimate against measurement, compound 3: 5 percentage points below, and the stated range covers the measured number.
By their numbers in this assay, from the lowest: compounds 1, 2 and 3 (each within the scatter of the next, the first and the last beyond it).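

In this assay the methoxy group entering ortho to a methoxy group gives a number 7 percentage points higher from compound 2 to compound 3 (within the scatter) and so, like the first methoxy step, does not by itself rise above the scatter. The two methoxy changes taken together do what neither shows alone: going from phenyl to 3,4-dimethoxyphenyl gives a number 11 percentage points higher from compound 1 to compound 3 (beyond the scatter) and is the only step shown that lies beyond the scatter, although it is a modest one. Nothing at hand explains this small gain, and the result can only be recorded as it stands.

The compounds shown leave open whether the gain belongs to methoxy groups in particular or would also appear with a hydroxy group, an ethoxy group or a chlorine atom on this ring. They also leave open whether the methoxy group that enters here would count for anything without the methoxy group it sits ortho to, and, with a single oral dose read, how the three compounds would compare at other doses.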